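Series notes: 3-chlorobenzyl for phenyl on compound 2

A few compounds are considered here, and "the series" means these few. Any claim that something is new, unique, unknown or untested is made for them only; others in the source may bear on it.

Compound 2 `Cc1nc(-c2ccccc2)oc1-c1csc(-c2ccccc2)n1` is the reference point for this step. In an ADME assay on A549 cells (Homo sapiens) for inhibition, read by MTT assay (on this read-out lower numbers stand for stronger inhibition of growth and higher numbers for weaker inhibition of growth), compound 2 gives > 250 ug/mL, which is a limit of the assay and not a number. Going by the values given here, compound 1 `Cc1nc(-c2ccc(F)cc2)oc1-c1csc(Cc2cccc(Cl)c2)n1` is the only other measured member of the series. In this assay compound 1 gives > 250 ug/mL, again a limit of the assay. Among the compounds with values here, both values shown thus sit at the same limit, as summarised by the limit of > 250 ug/mL in this assay, at which 2 of the 2 values shown sit, and no step between measured compounds can be computed.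

Compound 3 `Cc1nc(-c2ccccc2)oc1-c1csc(Cc2cccc(Cl)c2)n1` has not yet been measured. It differs from compound 2 by 3-chlorobenzyl in place of phenyl on an aromatic carbon. Since both measured compounds stand at the limit, no movement beyond the scatter is expected for the step that the limit leaves unreadable from compound 2 to compound 3. Compound 3 is therefore estimated to sit near 300 ug/mL in this assay, with a range from 120 ug/mL to 700 ug/mL, and most likely to be reported only as a limit.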

Compound 3, concentration for 50% growth inhibition: > 250 ug/mL
Compound 3: a limit, no number; the forecaster's own chance of this, stated with the estimate: 85%; the middle value does not contradict the limit.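

No step from compound 2 or compound 1 to compound 3 can be read in this assay because each value is a limit of the assay and not a number: the limit of > 250 ug/mL in this assay, at which 3 of the 3 values shown sit.

The compounds shown leave open whether 3-chlorobenzyl in place of phenyl, or hydrogen in place of fluoro, changes growth inhibition at all.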